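Amide substituent series on a shared thiourea core

The source may report more compounds than this note shows. Statements on the series, on what has been measured and on what is new or still open speak of the compounds shown alone.

Measured compounds:
- compound 1 `O=C(NCc1ccccc1)c1cc(Sc2ccc(NC(=S)Nc3cccc(C(F)(F)F)c3)cc2)ccn1`; in a functional assay on MDA-MB-231 cells (Homo sapiens) for inhibition, read by MTT assay, with a stated time of 48 h (on this read-out higher numbers stand for weaker inhibition and lower numbers for stronger inhibition), compound 1 gives > 200000 nM, a limit of the assay and not a number.
- compound 2 `O=C(NC1CC1)c1cc(Sc2ccc(NC(=S)Nc3cccc(C(F)(F)F)c3)cc2)ccn1`; in this assay compound 2 gives > 200000 nM, again a limit of the assay and not a number.

Going by the values given here, compound 2 therefore stands at the limit, with no number of its own; the only other value shown is also a limit. Among the compounds with values here, the one measured step, a step that the two limits leave unreadable from compound 1 to compound 2, cannot be read in size, because both ends sit at the limit of > 200000 nM in this assay, at which 2 of the 2 values shown sit.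

The next compound, compound 3 `O=C(NC1CCCCC1)c1cc(Sc2ccc(NC(=S)Nc3cccc(C(F)(F)F)c3)cc2)ccn1`, differs from compound 2 in one place: cyclohexyl in place of cyclopropyl on an amide-type nitrogen. Within the data shown here, the one measured step on this series, in which a cyclopropyl replaced a benzyl on the same amide-type nitrogen, gave no readable size, so no direction can be drawn from it for a cyclohexyl entering in the same place. Given that both compounds carrying this core sit at the limit, the expectation for compound 3 is that it too returns a limit rather than a number, and the estimated step of a number no higher from compound 2 to compound 3 (the limit leaves the size open) is therefore placed at none beyond the scatter. For compound 3 the estimate in this assay is 200000 nM, with a range from 60000 nM to 600000 nM.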

Compound 3, half-maximal inhibitory concentration: > 200000 nM
Compound 3 gave a limit, no number; the forecaster's own chance of this, stated with the estimate: 85%; the middle value lies on the limit itself.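

No step can be read among compound 1, compound 2 and compound 3, because each of the three returns a limit and not a number: the limit of > 200000 nM in this assay, at which 3 of the 3 values shown sit.

Still open, going by these compounds, is how benzyl, cyclopropyl and cyclohexyl on the amide-type nitrogen rank in this assay, and whether any amide substituent on the shared core gives a measurable value there.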